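Varying the aryl group on the amine-bearing chain

A few compounds are considered here, and "the series" means these few. Any claim that something is new, unique, unknown or untested is made for them only; others in the source may bear on it.

Three compounds share one core and differ only in the aromatic group on a saturated chain carbon bound to an amine nitrogen. Compound 1 `O=S(=O)(NCCCNCc1cccc2ccccc12)c1cc(C(F)(F)F)cc(C(F)(F)F)c1` carries naphthalen-1-yl there, compound 2 `COc1cccc(CNCCCNS(=O)(=O)c2cc(C(F)(F)F)cc(C(F)(F)F)c2)c1` a 3-methoxyphenyl, and compound 3 `O=S(=O)(NCCCNCc1ccc(C(F)(F)F)cc1)c1cc(C(F)(F)F)cc(C(F)(F)F)c1` a 4-(trifluoromethyl)phenyl. In a functional assay on HPAC cells (Homo sapiens) for inhibition, read by MTT assay, with a stated time of 72 h (a higher number here means a weaker inhibitor of growth, a lower number a stronger inhibitor of growth), compound 1 gives 2400 nM, compound 2 gives 2400 nM and compound 3 gives 2700 nM. Compound 3 stands at the high end of these three numbers, yet the steps of a 1.1-fold higher number from compound 1 to compound 3 (0.05 log units; within the scatter) and a 1.1-fold higher number from compound 2 to compound 3 (0.05 log units; within the scatter) are both within the scatter, as is no change at the digits printed from compound 1 to compound 2 (within the scatter). So far, exchanging one aromatic group for another at this position has not moved the result in this assay.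

Compound 4 `O=S(=O)(NCCCNCc1ccc(Cl)c(C(F)(F)F)c1)c1cc(C(F)(F)F)cc(C(F)(F)F)c1` continues the same kind of exchange: 4-chloro-3-(trifluoromethyl)phenyl in place of 4-(trifluoromethyl)phenyl on a saturated chain carbon bound to an amine nitrogen. Every measured step bears on it, since each also replaced the aromatic group at this position, and none of them reached beyond the scatter. The expectation is therefore a step of no change at the digits printed from compound 3 to compound 4 (within the scatter) from compound 3 to compound 4, that is, nothing beyond the scatter. Compound 4 is estimated at 2700 nM, with a likely range from 1400 nM to 5400 nM in this assay.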

Compound 4, concentration for 50% growth inhibition: 3000 nM
Estimate against measurement, compound 4: 1.1-fold (0.05 log units) below; the measured number falls inside the stated range.
By their numbers in this assay, from the lowest: compounds 1, 2, 3 and 4 (each within the scatter of the next).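

Among these compounds, compound 4 is the first of this set whose aromatic group carries a chlorine, and a 1.1-fold higher number from compound 3 to compound 4 (0.05 log units; within the scatter) in this assay shows that this addition leaves the result inside the usual scatter. The comparisons with the other two groups read the same way, with a 1.3-fold higher number from compound 2 to compound 4 (0.10 log units; within the scatter) and a 1.3-fold higher number from compound 1 to compound 4 (0.10 log units; within the scatter) as the steps, so the flat picture on this saturated chain carbon bound to an amine nitrogen now extends to a phenyl ring bearing both chlorine and trifluoromethyl. No measurement is at hand that would explain why these four aromatic groups cannot be told apart in this read-out.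

As far as these compounds go, all four groups are aromatic rings of carbon only and carry no hydrogen-bond donors, hydrogen-bond acceptors or net charge, so it remains open whether a pyridine ring, a carboxylic acid on the ring or a small alkyl group such as cyclohexyl would also leave the number in this range. The shared core is also constant throughout, which leaves open what a longer chain between the two nitrogens would do.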